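From a Branched to a Straight Chain End

A few compounds are considered here, and "the series" means these few. Any claim that something is new, unique, unknown or untested is made for them only; others in the source may bear on it.

Measured so far in a functional assay on K562 cells (Homo sapiens) for cytotoxicity, read by MTT assay, with a stated time of 72 h; on this read-out lower numbers stand for stronger inhibition and higher numbers for weaker inhibition
- Compound 1 `COCNc1n[n+]([O-])c2ccccc2[n+]1[O-]` gives 7800 nM
- Compound 2 `CCOCNc1n[n+]([O-])c2ccccc2[n+]1[O-]` gives 15400 nM
- Compound 3 `CC(C)CCOCNc1n[n+]([O-])c2ccccc2[n+]1[O-]` gives 13100 nM

The three compounds share a core and differ only in the chain on its oxygen. Compound 3, at 13100 nM, cannot be separated from compound 1 or compound 2, since all three values lie within the usual scatter of one another.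

Compound 4 `CCCCCOCNc1n[n+]([O-])c2ccccc2[n+]1[O-]` has propyl in place of isopropyl on a saturated chain carbon, two bonds along the chain from an oxygen on a saturated carbon. Among the measured compounds shown here, no measured pair swaps a branched chain for a straight one, so this change has not been tested directly. The nearest evidence is the step at that same place, a 1.2-fold lower number from compound 2 to compound 3 (0.07 log units; within the scatter). The other two steps on this chain are a 2.0-fold higher number from compound 1 to compound 2 (0.30 log units; within the scatter) and a 1.7-fold higher number from compound 1 to compound 3 (0.23 log units; within the scatter). None goes beyond the scatter, so no real shift is expected in this assay for this rearrangement of the same atoms. The expected step is a 1.0-fold lower number from compound 3 to compound 4 (0.00 log units; within the scatter). For compound 4 the estimate is 13000 nM, with an expected range of 7000 nM to 24000 nM.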

Compound 4, half-maximal inhibitory concentration: 14500 nM
Estimate against measurement, compound 4: 1.1-fold (0.05 log units) below; low and high end bracket the measured number.
By their numbers in this assay, from the lowest: compounds 1, 3, 4 and 2 (each within the scatter of the next).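

Swapping isopropyl for propyl at this place gives a 1.1-fold higher number from compound 3 to compound 4 (0.04 log units; within the scatter) in this assay, so this direct comparison of a branched and a straight chain end shows no real difference. The straight chain also stays within the scatter of the two shorter chains, with a 1.1-fold lower number from compound 2 to compound 4 (0.03 log units; within the scatter) and a 1.9-fold higher number from compound 1 to compound 4 (0.27 log units; within the scatter), and so the four compounds form a flat series with no trend in chain length or shape. Nothing available here explains this flat result.

The compounds shown leave open whether a much longer chain such as decyl, a chain carrying a phenyl ring, or a chain ending in an amine or a carboxylic acid would move the number beyond the scatter. They also leave open how changes to the shared core itself would read out, as all four compounds carry the same core.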